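Weighing a Larger Branch Where Methyl Made the Difference

The compounds below may be only part of what the source reports. "The series", "measured", "known", "first", "only" and "open" are said of these compounds alone.

Measured compounds:
- compound 1 `COc1cc(C(=O)NC2CCN(C)CC2)ccc1Nc1ncc2c(n1)N(C1CCCC1)[C@H](C)C(=O)N2C` — in an assay on isolated protein for inhibition of serine/threonine-protein kinase PLK1 (Homo sapiens), read by Z'-LYTE (on this read-out lower numbers stand for stronger inhibition and higher numbers for weaker inhibition), compound 1 gives 1.1 nM
- compound 2 `COc1cc(C(=O)NC2CCN(C)CC2)ccc1Nc1ncc2c(n1)N(C1CCCC1)CC(=O)N2C` — in this assay compound 2 gives 54.1 nM

Within the data shown here, only two numbers are known so far, and compound 2 holds the higher one; the single step between them, a 49-fold higher number from compound 1 to compound 2 (1.69 log units; beyond the scatter), shows a large change that rests on nothing more than a methyl group on a saturated ring carbon of the shared core.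

Compound 3 `COc1cc(C(=O)NC2CCN(C)CC2)ccc1Nc1ncc2c(n1)N(C1CCCC1)[C@H](CC(C)C)C(=O)N2C` is an untested variant. Compared with compound 2 it carries the following change: isobutyl in place of hydrogen on a saturated ring carbon. The same ring carbon that bears a methyl group in compound 1 and a hydrogen in compound 2 now carries the isobutyl group.

Among the measured compounds shown here, the only step that bears on this is a 49-fold higher number from compound 1 to compound 2 (1.69 log units; beyond the scatter), which reads, in reverse, as a strong drop in the number when a carbon substituent is placed at this site. Compound 3 puts a larger group there, so a drop in the number is expected in this assay, though its size is uncertain. For compound 3 the expected step is a 14-fold lower number from compound 2 to compound 3 (1.13 log units; beyond the scatter), and the estimate is 4 nM, with a range from 1 nM to 20 nM.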

Compound 3, half-maximal inhibitory concentration: 78 nM
Compound 3: the middle estimate sits 20-fold (1.29 log units) below what was measured, and the stated range ends below it.
By their numbers in this assay, from the lowest: compound 1; then compounds 2 and 3 (each within the scatter of the next).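

The earlier pair suggested that any carbon group on this saturated ring carbon might lower the number, but in this assay the isobutyl group gives only a 1.4-fold higher number from compound 2 to compound 3 (0.16 log units; within the scatter), so compound 3 cannot be told apart from compound 2, which carries a plain hydrogen at this site. Going from the methyl group to the isobutyl group, read as isopropyl in place of hydrogen on the saturated chain carbon bound to the ring, gives a 71-fold higher number from compound 1 to compound 3 (1.85 log units; beyond the scatter), so the gain seen with methyl in compound 1 does not carry over to this larger group. Nothing measured here explains why the methyl group and the isobutyl group part ways at this site.

The compounds shown leave open where the gain is lost between methyl and isobutyl, which ethyl, isopropyl or a longer straight chain on this ring carbon could help to locate. They also leave open what an amine or a hydroxyl group would do at this site, and how the mirror-image form of compound 1 at this carbon would compare.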